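This account rests on a few compounds, and the source may have more. Where it says the series, first, only, none or still open, it means among the compounds named here.

Of the compounds shown here, three with a shared core have been measured in an assay on isolated protein for agonist activity at prostaglandin E2 receptor EP4 subtype (Homo sapiens); a higher number here means that more compound is needed for the effect, a lower number that less compound is needed. Compound 1 `CC(C)(C)CCC1([C@H](O)/C=C/[C@H]2COC(=O)N2CCSc2nc(C(=O)O)cs2)CCC1` gives 4710 nM. Compound 2 `O=C(O)c1csc(SCCN2C(=O)OC[C@@H]2/C=C/[C@@H](O)C2(CCCCF)CCC2)n1` gives 195 nM. Compound 3 `CC#CCC1([C@H](O)/C=C/[C@H]2COC(=O)N2CCSc2nc(C(=O)O)cs2)CCC1` gives 240 nM, the second highest of the three numbers; its nearest neighbour is compound 2, and the two lie within the scatter of each other, while compound 1 lies far above both. The single-point steps show a 24-fold lower number from compound 1 to compound 2 (1.38 log units; beyond the scatter) and a 20-fold lower number from compound 1 to compound 3 (1.29 log units; beyond the scatter), whereas a 1.2-fold higher number from compound 2 to compound 3 (0.09 log units; within the scatter).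

Compound 4 `CCOCCC1([C@H](O)/C=C/[C@H]2COC(=O)N2CCSc2nc(C(=O)O)cs2)CCC1` has not been measured in this assay. Its change from compound 3 is ethoxymethyl in place of prop-1-yn-1-yl on a saturated chain carbon bound to a saturated ring carbon. Going by the values given here, two measured steps bear on this position. From compound 1 to compound 3 the exchange of neopentyl for prop-1-yn-1-yl was large, and from compound 2 to compound 3 the exchange of 3-fluoropropyl for prop-1-yn-1-yl stayed within the scatter. Ethoxymethyl, counted at four heavy atoms with one acceptor, is closer in size to the groups of compound 2 and compound 3 than to the neopentyl of compound 1, so the expected step in this assay from compound 3 to compound 4 is a 1.5-fold higher number from compound 3 to compound 4 (0.16 log units; within the scatter), small and not clearly beyond the scatter. Compound 4 is therefore estimated at 350 nM, with a range from 120 nM to 1000 nM.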

Compound 4, half-maximal effective concentration: 745 nM
Estimate against measurement, compound 4: 2.1-fold (0.33 log units) below; low and high end bracket the measured number.
By their numbers in this assay, from the lowest: compounds 2 and 3 (each within the scatter of the next); then compound 4; then compound 1.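

In this assay, the place on a saturated chain carbon bound to a saturated ring carbon proves less forgiving than the exchange between compound 2 and compound 3 suggested, as ethoxymethyl in place of prop-1-yn-1-yl gives a step beyond the scatter (a 3.1-fold higher number from compound 3 to compound 4 (0.49 log units; beyond the scatter)), and ethoxy in place of 2-fluoroethyl gives another (a 3.8-fold higher number from compound 2 to compound 4 (0.58 log units; beyond the scatter)). Closeness in heavy-atom count therefore does not by itself put a group level with compound 2 and compound 3. At the same time, the ethoxy end does not fall back as far as tert-butyl (a 6.3-fold lower number from compound 1 to compound 4 (0.80 log units; beyond the scatter)), so compound 4 sits apart from both the low pair and compound 1, and nothing measured here accounts for these differences.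

What the compounds shown leave open is whether the oxygen of the ethoxymethyl group or the chain as a whole carries the step from compound 3. A plain butyl chain with no oxygen, a methoxymethyl group or an amine at this place would bear on that question.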